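This account rests on a few compounds, and the source may have more. Where it says the series, first, only, none or still open, it means among the compounds named here.

Compound 3 `C[C@@H]1CN(c2cccc3c2C[C@H](CN(C)[C@H]2CCCc4cccnc42)NC3)C[C@H](C)N1C` stands lowest of the three numbers in a functional assay on CCRF-CEM cells for antagonist activity at C-X-C chemokine receptor type 4 (Homo sapiens), read by calcium flux, with stated times of 25 min and 90 s (a higher number here means a weaker inhibitor, a lower number a stronger inhibitor), with 14.1 nM. Compound 2 `CN1CCN(c2cccc3c2C[C@H](CN(C)[C@H]2CCCc4cccnc42)NC3)CC1` gives 29.6 nM and compound 1 `C[C@@H]1CN(c2cccc3c2C[C@H](CN(C)[C@H]2CCCc4cccnc42)NC3)C[C@H](C)N1` gives 61 nM. The steps were all modest: a 2.1-fold lower number from compound 1 to compound 2 (0.31 log units; beyond the scatter), a 4.3-fold lower number from compound 1 to compound 3 (0.64 log units; beyond the scatter) and a 2.1-fold lower number from compound 2 to compound 3 (0.32 log units; beyond the scatter). Compound 4 `CN(C[C@H]1Cc2c(cccc2N2C[C@@H]3C[C@H]2CN3)CN1)[C@H]1CCCc2cccnc21` brings (a group of 7 heavy atoms (5 carbon, 2 nitrogen; 2 five-membered non-aromatic rings with 1 hetero atom each) in place of a group of 9 heavy atoms (7 carbon, 2 nitrogen; one six-membered non-aromatic ring with 2 hetero atoms), on an aromatic carbon). The measured steps all change the group on that same aromatic carbon, and each moved the number by only a modest amount, so a similar-sized step in this assay is expected here. The entering group carries a ring nitrogen bearing hydrogen, as in compound 1, whose 61 nM was the highest, so the number for compound 4 is expected to rise somewhat, a 2.1-fold higher number from compound 3 to compound 4 (0.33 log units; beyond the scatter). Compound 4 is therefore estimated at 30 nM, within 10 nM to 90 nM.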

Compound 4, half-maximal inhibitory concentration: 146 nM
Compound 4: middle estimate off by 4.9-fold (0.69 log units), on the low side, and the stated range ends below it.
By their numbers in this assay, from the lowest: compound 3; then compound 2; then compound 1; then compound 4.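

In this assay, the group with two five-membered non-aromatic rings raises the number against every six-membered group at this aromatic carbon, most of all against 3,4,5-trimethylpiperazin-1-yl (a 10-fold higher number from compound 3 to compound 4 (1.02 log units; beyond the scatter)), and less against 4-methylpiperazin-1-yl (a 4.9-fold higher number from compound 2 to compound 4 (0.69 log units; beyond the scatter)). Even against compound 1, which also has a hydrogen on a ring nitrogen, the number rises (a 2.4-fold higher number from compound 1 to compound 4 (0.38 log units; beyond the scatter)), so that hydrogen alone does not bring the two level. Nothing measured here accounts for these rises. Still open, from the compounds shown here alone, is how a methyl on the entering group's ring nitrogen, or a morpholin-4-yl group at this carbon, would read.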